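This account rests on a few compounds, and the source may have more. Where it says the series, first, only, none or still open, it means among the compounds named here.

Within the data shown here, in a functional assay on U-251 cells (Homo sapiens) for inhibition, read by sulforhodamine B assay, with a stated time of 48 h, tested at 10 uM (on this read-out lower numbers stand for less inhibition and higher numbers for more inhibition at the one concentration tested (going by the name of the read-out)), compound 2 `O=Cc1ccc(-c2cn3ccnc3c(-c3ccc4ncn(C5CCCCC5)c4c3)n2)cc1` stands highest of the two numbers measured, giving 32%, while compound 1 `Brc1cn2ccnc2c(-c2ccc3ncn(C4CCCCC4)c3c2)n1` gives 1.5%; the one recorded step is a number 30.5 percentage points higher from compound 1 to compound 2 (beyond the scatter). Compound 3 `Fc1ccc(-c2cn3ccnc3c(-c3ccc4ncn(C5CCCCC5)c4c3)n2)cc1` differs from compound 2 by fluoro in place of formyl on an aromatic carbon. Among the measured compounds shown here, no measured step pairs formyl against fluoro. The step from compound 1 to compound 2 bears only loosely on it: exchanging bromo for 4-formylphenyl raised the number greatly, and the present change removes only the formyl. A smaller drop is expected, a number 18 percentage points lower from compound 2 to compound 3 (beyond the scatter). Compound 3 is therefore expected to show about 14%, between 0% and 32%.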

Compound 3, a percentage reported as inhibition, at one concentration (the size of the read-out at that concentration, not a potency): 7.94%
Compound 3: middle estimate off by 6.1 percentage points, on the high side; low and high end bracket the measured number.
By their numbers in this assay, from the lowest: compounds 1 and 3 (each within the scatter of the next); then compound 2.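

In this assay fluoro in place of formyl gives a number 24.1 percentage points lower from compound 2 to compound 3 (beyond the scatter) so the higher number of compound 2 goes with the formyl and not with the added phenyl ring alone. Likewise, 4-fluorophenyl in place of bromo gives a number 6.4 percentage points higher from compound 1 to compound 3 (within the scatter) and so the phenyl ring by itself does not separate compound 3 from compound 1. Nothing available explains why the formyl matters. On these data alone, whether an amine or a carboxylic acid on the same aromatic carbon would match the number of compound 2 stays open.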